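A few compounds are considered here, and "the series" means these few. Any claim that something is new, unique, unknown or untested is made for them only; others in the source may bear on it.

In a functional assay on HepG2 cells (Homo sapiens) for antiproliferative activity, read by MTT assay, with a stated time of 24 h (a higher number here means a weaker inhibitor, a lower number a stronger inhibitor), compound 1 `C#CCOc1ccc2c(=O)c(-c3cc(OC)c(OC)cc3OC)coc2c1` gives 4950 nM and compound 2 `COc1cc(OC)c(-c2coc3cc(OCc4ccccc4Br)ccc3c2=O)cc1OC` gives 2180 nM as the lower of the two numbers, which makes compound 2 the stronger inhibitor so far. For the measured compounds named here, the next molecule is compound 3 `COc1cc(OC)c(-c2coc3cc(OCc4cccc(C(F)(F)F)c4)ccc3c2=O)cc1OC`, which keeps the shared core and carries 3-(trifluoromethyl)phenyl in place of 2-bromophenyl on a saturated chain carbon bound to an oxygen on an aromatic ring as its only change. Going by the values given here, the one measured step at this place is a 2.3-fold lower number from compound 1 to compound 2 (0.36 log units; beyond the scatter) and it was modest, with 2-bromophenyl replacing ethynyl. Here one six-membered aromatic ring of carbon only replaces another, and no measured compound carries the new group, so no clear shift in either direction is expected. The expected change is a 1.1-fold higher number from compound 2 to compound 3 (0.06 log units; within the scatter) and so stays within the scatter. For compound 3 an estimated 2500 nM is expected, with a range from 1000 nM to 6000 nM as the likely span.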

Compound 3, half-maximal inhibitory concentration: 610 nM
Beside the measured number, compound 3's estimate is 4.1-fold (0.61 log units) above it; the measured number lies below the stated range.
By their numbers in this assay, from the lowest: compound 3; then compound 2; then compound 1.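

Swapping one aromatic ring for another on a saturated chain carbon bound to an oxygen on an aromatic ring is not a neutral change in this assay: it gives a 3.6-fold lower number from compound 2 to compound 3 (0.55 log units; beyond the scatter), so what the ring carries matters here, not just the presence of a ring. Measured against ethynyl, 3-(trifluoromethyl)phenyl gives an 8.1-fold lower number from compound 1 to compound 3 (0.91 log units; beyond the scatter), so this place accepts a group of 10 heavy atoms with a lower number, not a higher one. Nothing measured here explains the gain.

The bromine and the trifluoromethyl group differ both in identity and in their printed ring numbers, and the compounds shown do not separate the two, as they include neither 3-bromophenyl nor 2-(trifluoromethyl)phenyl. As far as these compounds go, how an amine or a carboxylic acid on this ring would behave also remains open.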